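The source may hold more compounds than are shown below. What is called first, only, known or untested is meant among the compounds shown, and "the series" means these compounds.

In a physicochemical assay for lipophilicity, using the shake flask method (on this read-out higher numbers stand for higher lipophilicity and lower numbers for lower lipophilicity), compound 1 (`CCCC(=O)N1CCC(NC(=O)Nc2ccc(C(F)(F)F)cc2)CC1`) stands at "not determined" (no result reported) and so offers no comparison. Among the compounds with values here, compound 2 (`CCC(C)C(=O)N1CCC(NC(=O)Nc2ccc(C(C)C)cc2)CC1`) gives 4.21 and thus holds the only number available in this assay so far. Compound 3 (`CCC(C)C(=O)N1CCC(NC(=O)Nc2ccc(C(C)(C)C)cc2)CC1`) is still to be measured, and its structure departs from that of compound 2 in a single place: methyl in place of hydrogen on a saturated chain carbon bound to an aromatic carbon and two saturated chain carbons (isopropyl to tert-butyl). Within the data shown here, with no measured step to go by, the expected change is a modest rise slightly beyond the scatter, estimated as a number 0.39 log units higher from compound 2 to compound 3 (beyond the scatter) in this assay here. Compound 3 is therefore expected at 4.6 (range 4.3 to 4.95) once measured.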

Compound 3, partition coefficient: 5.12
For compound 3 the middle estimate is 0.52 log units below the measured one, and the stated range ends below it.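

Isopropyl to tert-butyl gives a number 0.91 log units higher from compound 2 to compound 3 (beyond the scatter) in this assay and thus supplies the first measured step at this place. It shows that methyl in place of hydrogen on this saturated chain carbon, one added carbon, is enough to carry the read-out beyond the usual scatter. Nothing available accounts for the size of this step. From the compounds shown here alone, whether a cyclopropyl group or a methoxy group at this place would shift the read-out in the same direction remains open, and so does whether the step holds with another amide chain on the shared core.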